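The source may hold more compounds than are shown below. What is called first, only, known or untested is meant among the compounds shown, and "the series" means these compounds.

In a toxicity assay on L02 cells (Homo sapiens) for cytotoxicity, read by MTT assay, with a stated time of 72 h (a higher number here means a weaker inhibitor, a lower number a stronger inhibitor), three compounds sharing one core give values within the scatter of each other: compound 1 `O=C1c2c[n+]([O-])c3ccccc3c2C(=O)c2c1c1ccccc1n2Cc1cn([C@@H]2C[C@H](O)[C@@H](CO)O2)nn1` gives 630 nM, compound 2 `CC1(C)O[C@@H](CO)[C@H](Cn2cc(Cn3c4c(c5ccccc53)C(=O)c3c[n+]([O-])c5ccccc5c3C4=O)nn2)O1` gives 500 nM, and compound 3 `CC1(C)OC[C@H](Cn2cc(Cn3c4c(c5ccccc53)C(=O)c3c[n+]([O-])c5ccccc5c3C4=O)nn2)O1` gives 470 nM. Compound 4 `O=C1c2c[n+]([O-])c3ccccc3c2C(=O)c2c1c1ccccc1n2Cc1cn([C@@H]2O[C@H](CO)[C@@H](O)[C@H](O)[C@H]2O)nn1` has 3,4,5-trihydroxy-6-(hydroxymethyl)oxan-2-yl in place of the (2,2-dimethyl-1,3-dioxolan-4-yl)methyl of compound 3 on an aromatic nitrogen: 3,4,5-trihydroxy-6-(hydroxymethyl)oxan-2-yl in place of (2,2-dimethyl-1,3-dioxolan-4-yl)methyl on an aromatic nitrogen. The nearest evidence is a 1.3-fold lower number from compound 1 to compound 3 (0.13 log units; within the scatter), where 4-hydroxy-5-(hydroxymethyl)oxolan-2-yl gives way to that same group. Two further steps, a 1.3-fold lower number from compound 1 to compound 2 (0.10 log units; within the scatter) and a 1.1-fold lower number from compound 2 to compound 3 (0.03 log units; within the scatter), also stay within the scatter. No change beyond the scatter is therefore expected in this assay. The expected step is a 1.3-fold higher number from compound 3 to compound 4 (0.11 log units; within the scatter). For compound 4 the estimate is 600 nM, with an expected range of 250 nM to 1500 nM.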

Compound 4, half-maximal inhibitory concentration: 420 nM
For compound 4 the middle estimate is 1.4-fold (0.15 log units) above the measured one; low and high end bracket the measured number.
By their numbers in this assay, from the lowest: compounds 4, 3, 2 and 1 (each within the scatter of the next).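

In this assay, 3,4,5-trihydroxy-6-(hydroxymethyl)oxan-2-yl on the aromatic nitrogen leaves the number within the scatter of all three earlier groups: a 1.1-fold lower number from compound 3 to compound 4 (0.05 log units; within the scatter), a 1.2-fold lower number from compound 2 to compound 4 (0.08 log units; within the scatter) and a 1.5-fold lower number from compound 1 to compound 4 (0.18 log units; within the scatter). The earlier compounds shown here carried only five-membered non-aromatic rings here, so the flat result now extends to a six-membered non-aromatic ring with more hydrogen-bond donors. No available evidence accounts for this flatness. As far as these compounds go, whether an amine, a carboxylic acid or a longer alkyl chain at this nitrogen would move the number beyond the scatter remains open.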